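This account rests on a few compounds, and the source may have more. Where it says the series, first, only, none or still open, it means among the compounds named here.

Of the compounds shown here, three built on a shared fused two-ring core have been tested in a functional assay on the whole organism (strain Wistar Albino) for inhibition, with Rattus norvegicus as the target, read by paw edema, with a stated time of 2 h, at a dose of 20 mg/kg; a higher number here means more inhibition at the dose given (going by the name of the read-out), a lower number less inhibition. Compound 1 `COc1ccc(Cl)c(-c2nnc3sc(Cc4c(C)[nH]c5ccc(OC)cc45)nn23)c1` gives 20% in this assay. Compound 2 `COc1ccc2[nH]c(C)c(Cc3nn4c(-c5ccoc5C)nnc4s3)c2c1` gives 24.8% in this assay. The difference between these two is 2-methylfuran-3-yl in place of 2-chloro-5-methoxyphenyl on an aromatic carbon and the step that this change made is a number 4.8 percentage points higher from compound 1 to compound 2 (within the scatter). Compound 3 `COc1ccc(Cl)c(-c2nnc3sc(Cc4c[nH]c5ccccc45)nn23)c1` gives 16.5% in this assay; it carries the lowest of the three numbers, but its gaps to the other two both lie within the scatter, so no order among the three can be claimed. The difference between the core of compound 3 and the core of compound 1 is not broken down here.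

Compound 4 `Cc1occc1-c1nnc2sc(Cc3c[nH]c4ccccc34)nn12` has not yet been measured. It differs from compound 3 by 2-methylfuran-3-yl in place of 2-chloro-5-methoxyphenyl on an aromatic carbon. The leaving group, the entering group and the place are the same as in the earlier pair, so this is the same change, seen twice among the compounds shown. Within the data shown here, the only guide to its size is the single earlier step of a number 4.8 percentage points higher from compound 1 to compound 2 (within the scatter), which lay within the scatter. Resting on that, compound 4 is expected to sit close to compound 3, with an estimated step of a number 4.5 percentage points higher from compound 3 to compound 4 (within the scatter). Compound 4 is thus estimated to give 21% in this assay, with an expected range from 9% to 33%. The width of that range reflects an expectation resting on one prior step alone.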

Compound 4, a percentage reported as inhibition, in the whole organism at one dose (the size of the read-out at that dose, not a potency): 21.5%
The estimate for compound 4 lay 0.5 percentage points below the measured number, within the range that was stated.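

In this assay, putting 2-methylfuran-3-yl in place of 2-chloro-5-methoxyphenyl on the second core gives a number 5 percentage points higher from compound 3 to compound 4 (within the scatter). Set beside the step from the same change on the first core, the new step does not differ from it: the same change on two cores in this assay, a number 4.8 percentage points higher (within the scatter) from compound 1 to compound 2 and a number 5 percentage points higher (within the scatter) from compound 3 to compound 4, 0.2 percentage points apart, within the scatter of two such steps

So across the core of compound 1 and the core of compound 3, the change carried over with a step of much the same size, but each step lies within the scatter, so this agreement does not establish that the change has any real effect on inhibition in this assay, and two cores cannot show that it would hold on a third.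

The compounds shown leave open whether any group on this aromatic carbon, between two ring nitrogen atoms, could give a step beyond the scatter, since only 2-chloro-5-methoxyphenyl and 2-methylfuran-3-yl appear there, and an amine, a carboxylic acid or a longer alkyl chain in that place remains untested among them. They also leave open how these steps would read at other doses or stated times, as each value here reports the size of the read-out at a single dose and is not a potency.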